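The source may report more compounds than this note shows. Statements on the series, on what has been measured and on what is new or still open speak of the compounds shown alone.

Within the data shown here, compound 2 `O=C(O)C[C@@H]1CCN1c1ccc(OCc2ccc(Cl)cc2Cl)cc1` gives 440 nM in a functional assay on cells for agonist activity at Free fatty acid receptor 1 (Mus musculus), read by FLIPR and calcium flux, with a stated time of 100 s (on this read-out higher numbers stand for an effect only at larger amounts of compound and lower numbers for an effect already at smaller amounts), the only actual number among the two values shown. Compound 1 `O=C(O)C1CCN(c2ccc(OCc3ccc(Cl)cc3Cl)cc2)C1` reaches only the limit > 16000 nM in this assay. Among the measured compounds shown here, the single measured step, an at least 36-fold lower number from compound 1 to compound 2 (1.56 log units; beyond the scatter), is large and swaps one acid-bearing ring for another; it rests on (the limit of > 16000 nM in this assay, at which 1 of the 2 values shown sits). Compound 3 `O=C(O)C[C@H]1CCN1c1ccc(OCc2ccc(Cl)cc2Cl)cc1` differs from compound 2 only in configuration: the two compounds have the same atoms and bonds and differ only in configuration as drawn: 1 of 1 stereo elements differ; a stereocentre at a saturated ring carbon is drawn S in compound 2 and R in compound 3. For the measured compounds named here, no measured step changes configuration alone, so that step does not bear on this change. A weaker result is nevertheless expected for compound 3, with a step of a 6.8-fold higher number from compound 2 to compound 3 (0.83 log units; beyond the scatter). Compound 3 is estimated at 3000 nM, between 600 nM and 16000 nM.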

Compound 3, half-maximal effective concentration: > 17000 nM
Compound 3: only a limit was reported (the forecaster's own chance of this, stated with the estimate: 25%); middle value at least 5.6-fold (0.75 log units) from the limit.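

Turning the one stereocentre at a saturated ring carbon from S to R gives an at least 38-fold higher number from compound 2 to compound 3 (1.58 log units; beyond the scatter) in this assay, so at this position the configuration as drawn separates a measured number from a mere limit: the fact that compounds 2 and 3 differ only in the configuration as drawn. The size of this step is itself open-ended, since the value of compound 3 is a limit and not a number: the limit of > 17000 nM in this assay, at which 1 of the 3 values shown sits. The step from compound 1 to compound 3 cannot be read, as both values are limits.

Going by these compounds, how far compound 3 truly lies from compound 2 remains open. Also open, on these data alone, is whether the number of compound 2 holds when the carboxymethyl group gives way to a longer chain ending in a carboxylic acid.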